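Fluoro on the fused ring of the shared core

The source may hold more compounds than are shown below. What is called first, only, known or untested is meant among the compounds shown, and "the series" means these compounds.

Measured compounds:
compound 1 `C[Si](C)(C)C#Cc1cc(-c2nc3ccccc3s2)ccc1N`: 560 nM
compound 2 `C[Si](C)(C)C#Cc1cc(-c2nc3c(F)cccc3s2)ccc1N`: 230 nM

Of the compounds shown here, two have been measured in a functional assay on MDA-MB-468 cells (Homo sapiens) for inhibition, with a stated time of 72 h; on this read-out higher numbers stand for weaker inhibition of growth and lower numbers for stronger inhibition of growth. Compound 1 has the core without a fluoro group, and in this assay compound 1 gives 560 nM, the highest of the two numbers, so the weaker of the two at slowing growth. Compound 2 carries a fluoro group on one aromatic carbon of the fused ring, and the change gives a 2.4-fold lower number from compound 1 to compound 2 (0.39 log units; beyond the scatter).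

Compound 3 `C[Si](C)(C)C#Cc1cc(-c2nc3cc(F)ccc3s2)ccc1N` is not yet measured. It differs from compound 1 by fluoro in place of hydrogen on an aromatic carbon, the same kind of change as in compound 2 but at a different aromatic carbon of the fused ring. Within the data shown here, the only step that bears on it is a 2.4-fold lower number from compound 1 to compound 2 (0.39 log units; beyond the scatter), a modest gain. Since the fluoro group sits elsewhere in compound 3, the gain is expected to be of similar or somewhat smaller size, in the same direction, giving an expected step of a 1.6-fold lower number from compound 1 to compound 3 (0.20 log units; within the scatter). Compound 3 is therefore estimated at 350 nM, with a likely range from 170 nM to 750 nM.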

Compound 3, concentration for 50% growth inhibition: 210 nM
Compound 3: the middle estimate sits 1.7-fold (0.22 log units) above what was measured, and the stated range covers the measured number.
By their numbers in this assay, from the lowest: compounds 3 and 2 (each within the scatter of the next); then compound 1.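

In this assay the change to compound 3 gives a 2.7-fold lower number from compound 1 to compound 3 (0.43 log units; beyond the scatter) and so shows that the lower number from fluoro in place of hydrogen is not tied to the single aromatic carbon changed in compound 2, since a second carbon of the same six-membered aromatic ring of carbon only gives it as well. Compound 2 gives 230 nM and compound 3 gives 210 nM in the same read-out; these two numbers lie within the usual scatter of each other, so this read-out does not separate the two placements. No measurement at hand explains why fluoro at either carbon goes with stronger inhibition of growth.

The compounds shown leave open whether the other aromatic carbons of that ring would respond in the same way, and whether two fluoro groups on one core, one at each of these carbons, would lower the number further. They also leave open whether a different group at these same carbons, such as chloro, methoxy or trifluoromethyl, would give a similar step.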